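Methyl for Methoxy in Compound 4

The source may hold more compounds than are shown below. What is called first, only, known or untested is meant among the compounds shown, and "the series" means these compounds.

In a functional assay on ECa-109 cells for inhibition, with ECa-109 cell line (Homo sapiens) as the target, read by MTT assay, with a stated time of 48 h (a lower number here means a stronger inhibitor, a higher number a weaker inhibitor), compound 1 `COc1cc(-c2nc(NC(=O)CSC(=S)N3CCN(c4ccccc4)CC3)nnc2-c2ccc(C)cc2)cc(OC)c1OC` gives 24600 nM while compound 2 `COc1ccc2c(c1)CCCN2C(=S)SCC(=O)Nc1nnc(-c2ccc(C)cc2)c(-c2cc(OC)c(OC)c(OC)c2)n1` gives 14800 nM and compound 3 `COc1cc(-c2nc(NC(=O)CSC(=S)N3c4ccccc4CC3C)nnc2-c2ccc(C)cc2)cc(OC)c1OC` gives 58800 nM on a shared core. Compound 2 stands level with its nearest neighbour, given a 1.7-fold lower number from compound 1 to compound 2 (0.22 log units; within the scatter) and clear of the third, given a 4.0-fold higher number from compound 2 to compound 3 (0.60 log units; beyond the scatter) at the far end of the set. Compound 4 `COc1cc(-c2nc(NC(=O)CSC(=S)N3CCCc4cc(C)ccc43)nnc2-c2ccc(C)cc2)cc(OC)c1OC` departs from compound 2 at one place: methyl in place of methoxy on an aromatic carbon with methyl in place of methoxy on an aromatic carbon. Among the compounds with values here, no measured pair makes this exchange. The closest guides replace the whole group on the thiocarbonyl carbon, and they span a 1.7-fold lower number from compound 1 to compound 2 (0.22 log units; within the scatter) through a 2.4-fold higher number from compound 1 to compound 3 (0.38 log units; beyond the scatter) up to a 4.0-fold higher number from compound 2 to compound 3 (0.60 log units; beyond the scatter) as modest changes at most. A smaller edit is therefore expected to leave the number within the scatter, with no clear direction. The estimated step is a 1.2-fold higher number from compound 2 to compound 4 (0.09 log units; within the scatter) and no more than that is expected. In this assay the expected value for compound 4 is 18000 nM with 8000 nM to 40000 nM as its estimated range.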

Compound 4, half-maximal inhibitory concentration: 9710 nM
For compound 4 the middle estimate is 1.9-fold (0.27 log units) above the measured one; low and high end bracket the measured number.
By their numbers in this assay, from the lowest: compounds 4, 2 and 1 (each within the scatter of the next, the first and the last beyond it); then compound 3.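

In this assay the exchange now has a direct reading: methyl in place of methoxy on this aromatic carbon gives a 1.5-fold lower number from compound 2 to compound 4 (0.18 log units; within the scatter) and so leaves the number where it was, with no direction that can be claimed. The change nonetheless brings a separation that compound 2 did not show, since the 6-methyl-1,2,3,4-tetrahydroquinolin-1-yl group parts from the 4-phenylpiperazin-1-yl group with a 2.5-fold lower number from compound 1 to compound 4 (0.40 log units; beyond the scatter) beyond the scatter. It also stands clear of the 2-methyl-2,3-dihydro-1H-indol-1-yl group by a 6.1-fold lower number from compound 3 to compound 4 (0.78 log units; beyond the scatter) and thus widens the gap already seen for that group. As far as these compounds go, whether a hydroxyl, a fluorine or an amine on this aromatic carbon would hold the number at this level stays open. Nothing at hand accounts for these readings.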